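The source may report more compounds than this note shows. Statements on the series, on what has been measured and on what is new or still open speak of the compounds shown alone.

In a functional assay on SW-620 cells (Homo sapiens) (on this read-out lower numbers stand for stronger inhibition and higher numbers for weaker inhibition), the measured compounds are:
- compound 1 `COc1cc(NC(C)CCCNC(=O)NCCCO)c2ncccc2c1`: > 100000 nM (a limit)
- compound 2 `COc1cc(NC(C)CCCNC(=O)NCCCCCO)c2ncccc2c1`: 200 nM
- compound 3 `COc1cc(NC(C)CCCNC(=O)N(CCO)CCO)c2ncccc2c1`: > 100000 nM (a limit)

Compound 3 has no number, only the limit > 100000 nM. It stands at the limit of > 100000 nM in this assay, at which 2 of the 3 values shown sit, together with compound 1.

Compound 4 `COc1cc(NC(C)CCCNC(=O)NO)c2ncccc2c1` carries hydroxyamino in place of bis(2-hydroxyethyl)amino on a carbonyl carbon.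

Three measured steps alter the same substituent on this carbonyl carbon. Two are large: an at least 500-fold lower number from compound 1 to compound 2 (2.69 log units; beyond the scatter) and an at least 500-fold higher number from compound 2 to compound 3 (2.69 log units; beyond the scatter). The third, a step that the two limits leave unreadable from compound 1 to compound 3, cannot be sized. Together they show that a change here can move the read-out strongly, but only compound 2 has so far escaped the limit, and none of the three carries hydroxyamino. A move to a lower number is therefore expected, though a smaller one than those steps, and another limit remains possible.

For compound 4, the expected value is 30000 nM, with an estimated range from 3000 nM to 100000 nM. This estimate means an at least 3.3-fold lower number from compound 3 to compound 4 (0.52 log units; beyond the scatter).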

Compound 4, half-maximal inhibitory concentration: 35000 nM
Compound 4: middle estimate off by 1.2-fold (0.07 log units), on the low side; measured number inside the range.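

In this assay, compound 4 shows that the substituent on this carbonyl carbon does not need a long chain to give a measurable inhibition, which sets it apart from the two compounds held at a limit: the limit of > 100000 nM in this assay, at which 2 of the 4 values shown sit.

Hydroxyamino gives an at least 2.8-fold lower number from compound 3 to compound 4 (0.45 log units; beyond the scatter) and an at least 2.8-fold lower number from compound 1 to compound 4 (0.45 log units; beyond the scatter), so the read-out does not simply follow chain length, since 3-hydroxypropyl gives only a limit while the shorter hydroxy gives a number. Even so, 5-hydroxypentyl remains the strongest of the groups shown, with a 180-fold higher number from compound 2 to compound 4 (2.24 log units; beyond the scatter).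

Going by these compounds, what drives this uneven order stays open, as four compounds cannot separate the effects of chain length and the hydroxy group. It is also unknown whether a longer chain, or an amine or a carboxylic acid in place of the hydroxy of 5-hydroxypentyl, would keep the strength of compound 2.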